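Removing the carboxy group: compound 1 to compound 4

The source may report more compounds than this note shows. Statements on the series, on what has been measured and on what is new or still open speak of the compounds shown alone.

Measured compounds in a functional assay on CRL2813 cells (Homo sapiens) for cytotoxicity, read by sulforhodamine B assay, with a stated time of 5 days; a lower number here means a stronger inhibitor, a higher number a weaker inhibitor:
- compound 1, `O=C(Nc1cccc(C(=O)O)c1)N[C@H]1CC[C@H](Oc2ccc(F)cc2)CC1`: > 20000 nM
- compound 2, `O=C(Nc1cccc(Br)c1)N[C@H]1CC[C@H](Oc2ccc(F)cc2)CC1`: 6200 nM
- compound 3, `O=C(Nc1ccc(F)cc1)N[C@H]1CC[C@H](Oc2ccc(F)cc2)CC1`: 20000 nM

The value shown for compound 1 is a limit of the assay and not a number, so compound 1 stands at the weak end of the set (the limit of > 20000 nM in this assay, at which 1 of the 3 values shown sits). Compound 4, `O=C(Nc1ccccc1)N[C@H]1CC[C@H](Oc2ccc(F)cc2)CC1`, has not yet been measured. It differs from compound 1 in one place: hydrogen in place of carboxy on an aromatic carbon. Going by the values given here, only one measured step starts from compound 1 and changes the same group: an at least 3.2-fold lower number from compound 1 to compound 2 (0.50 log units; beyond the scatter). That step shows that taking the carboxy group away can give a stronger inhibitor, but it also adds a bromo group, so it does not isolate the loss of carboxy. The step of a 3.2-fold higher number from compound 2 to compound 3 (0.51 log units; beyond the scatter) shows that a halogen pattern without bromo lands back near compound 3. Compound 4 carries neither group, so a number between compound 2 and compound 3 is expected, meaning a step of an at least 1.6-fold lower number from compound 1 to compound 4 (0.22 log units; that floor lies within the scatter) in this assay. Compound 4 is therefore estimated at 12000 nM, with a range from 5000 nM to 30000 nM.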

Compound 4, half-maximal inhibitory concentration: 20000 nM
Estimate against measurement, compound 4: 1.7-fold (0.22 log units) below; low and high end bracket the measured number.
By their numbers in this assay, from the lowest: compound 2; then compounds 3 and 4 (each within the scatter of the next).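

In this assay, going by these compounds alone, compound 4 gives the first reading of the ring with no group on it, and removing the fluoro group shows no change at the digits printed from compound 3 to compound 4 (within the scatter). Hydrogen in place of bromo gives a 3.2-fold higher number from compound 2 to compound 4 (0.51 log units; beyond the scatter), so among these compounds only the bromo group sets the number apart from that of the bare phenyl ring. Hydrogen in place of carboxy gives a number no higher from compound 1 to compound 4 (the limit leaves the size open). The size of that step cannot be read, because the value for compound 1 is a limit and not a number: the limit of > 20000 nM in this assay, at which 1 of the 4 values shown sits.

As far as these compounds go, how far the carboxy group weakens compound 1 relative to the bare ring therefore stays open. Also open, from the compounds shown here alone, is how a chloro, methyl or amine group on the same aromatic carbon as the bromo group would compare with compound 2.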